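The source may report more compounds than this note shows. Statements on the series, on what has been measured and on what is new or still open speak of the compounds shown alone.

Measured compounds in a functional assay on CHO cells for agonist activity at adenosine receptor A1 (Homo sapiens), read by fluorescence and ERK phosphorylation, with stated times of 30 min and 1.5 h, tested at 3 uM; on this read-out lower numbers stand for a weaker effect and higher numbers for a stronger effect at the one concentration tested:
- compound 1, `Nc1scc(-c2ccccc2)c1C(=O)c1ccccc1`: 49%
- compound 2, `Nc1scc(-c2ccc(Br)cc2)c1C(=O)c1ccccc1`: 46%

Compound 1 stands together with compound 2; the gap between the two is within the scatter, so the pair is not told apart on this read-out. Among the compounds with values here, the one step measured so far, a number 3 percentage points lower from compound 1 to compound 2 (within the scatter), is bromo in place of hydrogen on an aromatic carbon, a change on the pendant six-membered ring of the shared core.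

Compound 3, `Nc1scc(-c2cccc([N+](=O)[O-])c2)c1C(=O)c1ccccc1`, is not yet measured. It differs from compound 1 as follows: nitro in place of hydrogen on an aromatic carbon. Within the data shown here, it is a substituent on the same pendant ring as the bromo of compound 2, so the bromo step is the only measured step that bears on it. That step gave no change beyond the scatter. The nitro group is a different group at a different place on the ring, so the bromo step is a loose guide only.

On this basis no step beyond the scatter is expected from compound 1 to compound 3 in this assay, because a number 3 percentage points lower from compound 1 to compound 2 (within the scatter) was itself within the scatter; the expected step is a number 4 percentage points lower from compound 1 to compound 3 (within the scatter). Compound 3 is estimated at 45%, in the range 25% to 65%.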

Compound 3, a percentage reported as activity, at one concentration (the size of the read-out at that concentration, not a potency): 47%
For compound 3 the middle estimate is 2 percentage points below the measured one; the range from low to high includes it.
By their numbers in this assay, from the lowest: compounds 2, 3 and 1 (each within the scatter of the next).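

Read in this assay the change to nitro in place of hydrogen on an aromatic carbon, meta to a large group, gives a number 2 percentage points lower from compound 1 to compound 3 (within the scatter) and adds a first reading at this place on the six-membered aromatic ring of carbon only. The entering group has 3 heavy atoms, 2 hydrogen-bond acceptors and no net charge, yet at this one concentration compound 3 is not told apart from compound 1, so this place accepts nitro without a step beyond the scatter. No measurement at hand accounts for this result.

As far as these compounds go, an amine, a carboxylic acid or a longer chain such as butyl at this same place remains open, as does the question of whether any of these would give a step beyond the scatter in this assay on the shared core. Also open is how a substituent on the other aromatic ring of the shared core would read, and, with only one concentration shown, whether compounds that read alike here also match in potency.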